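A Second Chloro on Two Compounds at the Limit

The source may hold more compounds than are shown below. What is called first, only, known or untested is meant among the compounds shown, and "the series" means these compounds.

In a functional assay on CUTLL1 cells (Homo sapiens) for inhibition, read by resazurin assay, with a stated time of 48 h, in the presence of a further agent that is not named here (a higher number here means that more compound is needed for the effect, a lower number that less compound is needed), compound 1 (`Nc1ncc(-c2ccnc(F)c2)c(C2CC2)n1`) gives > 100000 nM, which is a limit of the assay and not a number. Compound 2 (`Nc1ncc(-c2ccnc(Cl)c2)c(C2CC2)n1`) gives > 100000 nM, which is likewise a limit. For the measured compounds named here, the only measured step is a step that the two limits leave unreadable from compound 1 to compound 2, so chloro in place of fluoro has no readable size. The whole record so far is the limit of > 100000 nM in this assay, at which 2 of the 2 values shown sit, and compound 2 therefore has no numerical position, only a limit.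

Compound 3 (`Nc1ncc(-c2cc(Cl)nc(Cl)c2)c(C2CC2)n1`) differs from compound 2 by one change: chloro in place of hydrogen on an aromatic carbon. Going by the values given here, no measured step bears directly on adding a chloro in place of hydrogen, and the one step available offers no size to carry over. The expectation therefore rests only on compound 1 and compound 2 both sitting at the limit of > 100000 nM in this assay, at which 2 of the 2 values shown sit. In this assay, compound 3 is expected to stay close to that limit and may well be reported as a limit again, with any shift more likely towards lower concentrations. The expected change is an at least 1.2-fold lower number from compound 2 to compound 3 (0.09 log units; that floor lies within the scatter). For compound 3 the estimated half-maximal effective concentration is 80000 nM, with an expected range from 20000 nM to 200000 nM.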

Compound 3, half-maximal effective concentration: 7600 nM
Compound 3: the middle estimate sits 11-fold (1.02 log units) above what was measured; measured number outside the range, below it.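

In this assay, for the compounds shown here, chloro in place of hydrogen on an aromatic carbon, next to the ring nitrogen and meta to a chloro group, brings the first readable change in this set: an at least 13-fold lower number from compound 2 to compound 3 (1.11 log units; beyond the scatter). One end of that step is a limit of the assay and not a number, so the printed size is only a floor. Going by these compounds alone, compound 3, at 7600 nM, is the one compound here with a measured number. The earlier pair could not show that this position responds to any change at all, and the record now holds one value clear of the limit while the others remain at it: the limit of > 100000 nM in this assay, at which 2 of the 3 values shown sit.

Going by these compounds, the step between the two earlier compounds cannot be read, so it stays open whether fluoro in place of the first chloro, with the new chloro kept, would leave the number where it is. Nor do the compounds shown tell whether the drop belongs to chloro in particular, or whether a methyl, a methoxy or an amine on the same aromatic carbon would bring a similar one.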